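The source may hold more compounds than are shown below. What is called first, only, known or untested is meant among the compounds shown, and "the series" means these compounds.

Measured compounds in the series:

Compound 1, `O=C1[C@@H](Cc2n[nH]c3ccccc23)C(=O)N(c2ccccc2)C=CN1CC(=O)N1CCCCc2ccccc21`, gives 1.59 nM in a functional assay on CHO cells for agonist activity at Melanocyte-stimulating hormone receptor (Homo sapiens), read by a luciferase reporter, with a stated time of 4 h; a higher number here means that more compound is needed for the effect, a lower number that less compound is needed.
Compound 2, `O=C1C(Cc2n[nH]c3cc(F)ccc23)C(=O)N(c2ccccc2)C=CN1CC(=O)N1CCCCc2ccccc21`, gives 1.59 nM in this assay.
Compound 3, `COc1ccc(N(C(=O)CN2C=CN(c3ccccc3)C(=O)[C@H](Cc3n[nH]c4ccccc34)C2=O)C(C)C)cc1`, gives 15.9 nM in this assay.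

Compound 1 and compound 3 share a core and differ at one place only: a group of 12 heavy atoms (10 carbon, 1 nitrogen, 1 oxygen; one six-membered aromatic ring of carbon only) in place of a group of 11 heavy atoms (10 carbon, 1 nitrogen; one six-membered aromatic ring of carbon only, one seven-membered non-aromatic ring with 1 hetero atom), on a carbonyl carbon. That exchange moved the read-out by a 10-fold higher number from compound 1 to compound 3 (1.00 log units; beyond the scatter). Compound 2 carries a core that differs from the core of compound 1, and the difference between the two cores is not broken down here; the values of compound 1 and compound 2 are level at the digits shown and lie within the usual scatter of each other, so no order between them can be read from these two numbers.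

Compound 4, `COc1ccc(N(C(=O)CN2C=CN(c3ccccc3)C(=O)C(Cc3n[nH]c4cc(F)ccc34)C2=O)C(C)C)cc1`, has not yet been measured in this assay. It stands to compound 2 exactly as compound 3 stands to compound 1: a group of 12 heavy atoms (10 carbon, 1 nitrogen, 1 oxygen; one six-membered aromatic ring of carbon only) in place of a group of 11 heavy atoms (10 carbon, 1 nitrogen; one six-membered aromatic ring of carbon only, one seven-membered non-aromatic ring with 1 hetero atom), on a carbonyl carbon. The place line is the same word for word in both pairs, so this is the same change made on the second core.

The expectation for compound 4 rests on a single precedent, and it is a modest one. Because compound 2 sits at 1.59 nM and the same exchange on compound 1 gave a 10-fold higher number from compound 1 to compound 3 (1.00 log units; beyond the scatter), the step from compound 2 to compound 4 is expected to be about a 9.4-fold higher number from compound 2 to compound 4 (0.97 log units; beyond the scatter) in this assay. Going by these compounds, whether the second core carries the change in the same way is untested; one measured pair does not establish a pattern. Compound 4 is therefore estimated at 15 nM in this assay, with a plausible range from 5 nM to 50 nM.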

Compound 4, half-maximal effective concentration: 1.59 nM
Compound 4: middle estimate off by 9.4-fold (0.97 log units), on the high side; measured number outside the range, below it.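

On the core of compound 2, putting isopropyl(4-methoxyphenyl)amino in place of the group with the seven-membered non-aromatic ring, on the carbonyl carbon, gives no change at the digits printed from compound 2 to compound 4 (within the scatter) in this assay. The exchange therefore does not carry over from one core to the other as a step of fixed size in this series: the same change on two cores in this assay, a 10-fold higher number (1.00 log units; beyond the scatter) from compound 1 to compound 3 and no change at the digits printed (within the scatter) from compound 2 to compound 4, 10-fold (1.00 log units) apart, beyond the scatter of two such steps. Going by these compounds alone, these two pairs show only that the step is not the same on both cores; they do not show which difference between the cores goes with the gap, and two pairs set no rule for predicting the step on any further core.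

Still open, going by these compounds, is whether a smaller group on the same carbonyl carbon, such as diethylamino or piperidine, would also give steps that differ between the two cores. Also open, on these data alone, is whether a chlorine or a methoxy group in place of the fluorine of compound 2 and compound 4 would give a core that follows compound 2 and compound 4 or compound 1 and compound 3 in this exchange.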